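Swapping cyclopropyl for ethynyl on the amide carbonyl

The compounds below may be only part of what the source reports. "The series", "measured", "known", "first", "only" and "open" are said of these compounds alone.

Compound 1, `C/C=C/C(=O)N(Cc1cccc(O)c1)c1cc(OC)c(OC)c(OC)c1`, gives 6700 nM in a functional assay on HCT-116 cells (Homo sapiens) for inhibition, read by MTT assay, with a stated time of 48 h; on this read-out higher numbers stand for weaker inhibition and lower numbers for stronger inhibition.
Compound 2, `COc1ccc(CN(C(=O)C2CC2)c2cc(OC)c(OC)c(OC)c2)cc1O`, gives 49 nM.
Compound 3, `C/C=C/C(=O)N(Cc1ccc(OC)c(C)c1)c1cc(OC)c(OC)c(OC)c1`, gives 23500 nM.

Compound 2 stands lowest of the three numbers, far beyond the scatter from both others, so it is the strongest inhibitor of the set. Compound 4, `C#CC(=O)N(Cc1ccc(OC)c(O)c1)c1cc(OC)c(OC)c(OC)c1`, differs from it in one place: ethynyl in place of cyclopropyl on a carbonyl carbon. For the measured compounds named here, the only measured step, a 3.5-fold higher number from compound 1 to compound 3 (0.54 log units; beyond the scatter), concerns the ring on the saturated chain carbon, not the carbonyl carbon, so it does not bear on this change, and no pair of measured compounds differs only at the carbonyl. With nothing to go on, the expected step of a 2.0-fold higher number from compound 2 to compound 4 (0.31 log units; beyond the scatter) is set near none, though a shift beyond the scatter either way cannot be excluded. Compound 4 is therefore expected to give 100 nM, with a range from 25 nM to 400 nM.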

Compound 4, half-maximal inhibitory concentration: 310 nM
For compound 4 the middle estimate is 3.1-fold (0.49 log units) below the measured one; low and high end bracket the measured number.
By their numbers in this assay, from the lowest: compound 2; then compound 4; then compound 1; then compound 3.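

In this assay, for the compounds shown here, ethynyl in place of cyclopropyl on a carbonyl carbon gives a 6.3-fold higher number from compound 2 to compound 4 (0.80 log units; beyond the scatter) and is the first measured change at this position. It shows that the group here affects the read-out, with cyclopropyl giving the stronger inhibition of these two. Nothing measured here accounts for the loss.

On these data alone, whether cyclobutyl, a longer chain such as propyl, or an amine on this carbonyl carbon would keep or lose inhibition stays open. So does whether this swap has the same size on the rings carried by compound 1 and compound 3.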